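Swapping methyl for 2-phenylethynyl: a solubility forecast

The compounds below may be only part of what the source reports. "The series", "measured", "known", "first", "only" and "open" are said of these compounds alone.

Compound 1 `Cc1ccccc1C(=O)Nc1cc(Cl)ccn1`: 25 ug/mL
Compound 2 `Cc1ccnc(NC(=O)c2ccccc2C)c1`: > 100 ug/mL
Compound 3 `Cc1ccccc1C(=O)Nc1cc(C#Cc2ccccc2)ccn1`: not yet measured

In a physicochemical assay for solubility, read by nephelometry, measured as kinetic solubility, at pH 2, tested at 10 mg/mL (on this read-out lower numbers stand for lower solubility and higher numbers for higher solubility), compound 2 reads > 100 ug/mL and this is a limit of the assay, not a number. The change to compound 3 is 2-phenylethynyl in place of methyl on an aromatic carbon and it puts 2-phenylethynyl in place of methyl on an aromatic carbon opposite the ring nitrogen. In this assay compound 1 gives 25 ug/mL as a true number and so offers the only firm anchor. Going by the values given here, only one measured step bears on the change, namely an at least 4.0-fold higher number from compound 1 to compound 2 (0.60 log units; beyond the scatter) for methyl in place of chloro on an aromatic carbon. That step shows a single swap of this kind moving the read-out clearly, and the group entering now is much bigger and carbon only, so a lower number is expected. The expected change is an at least 10-fold lower number from compound 2 to compound 3 (1.00 log units; beyond the scatter) and would lie beyond the scatter. Compound 3 is estimated at 10 ug/mL with an expected range from 3 ug/mL to 35 ug/mL in this measurement.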

Compound 3, solubility: 1.6 ug/mL
Estimate against measurement, compound 3: 6.3-fold (0.80 log units) above, and the stated range ends above it.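

In this assay, 2-phenylethynyl in place of chloro opposite the ring nitrogen gives a 16-fold lower number from compound 1 to compound 3 (1.19 log units; beyond the scatter), a step with true numbers at both ends, so this position can push the read-out down as well as up. Measured against methyl, the change gives an at least 62-fold lower number from compound 2 to compound 3 (1.79 log units; beyond the scatter), and the real gap could be larger still. Compound 2 reads at a limit of the assay, not a number: the limit of > 100 ug/mL in this assay, at which 1 of the 3 values shown sits.

The compounds shown cannot separate the part played by the triple bond from that of the added ring within 2-phenylethynyl, and a plain ethynyl group or a phenyl group at this position would be needed to pull them apart. From the compounds shown here alone, what an amine or a carboxylic acid would do at the same position also remains open.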